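This account rests on a few compounds, and the source may have more. Where it says the series, first, only, none or still open, it means among the compounds named here.

- compound 1 `CC(=O)N[C@@H]1CCC[C@H](C(=O)Nc2cc(-c3cnc4n3CCC4)c(Cl)cn2)C1` with 2.6 
- compound 2 `CC(=O)N[C@@H]1CCC[C@H](C(=O)Nc2cc(-c3cnn4c3CCCCC4)c(Cl)cn2)C1` with 3.6 

In a physicochemical assay for lipophilicity, using the shake flask method, measured as octanol-water partition, at pH 7.4 (on this read-out lower numbers stand for lower lipophilicity and higher numbers for higher lipophilicity), compound 2 stands highest of the two measured compounds at 3.6 on these numbers. Compound 3 `CC(=O)N[C@@H]1CCC[C@H](C(=O)Nc2cc(-c3cnn4c3COCC4)c(Cl)cn2)C1` makes one change to compound 2 (a group of 9 heavy atoms (6 carbon, 2 nitrogen, 1 oxygen; one five-membered aromatic ring with 2 hetero atoms, one six-membered non-aromatic ring with 2 hetero atoms) in place of a group of 10 heavy atoms (8 carbon, 2 nitrogen; one five-membered aromatic ring with 2 hetero atoms, one seven-membered non-aromatic ring with 1 hetero atom), on an aromatic carbon). Among the compounds with values here, the one measured step bearing on this is a number 1.00 log units higher from compound 1 to compound 2 (beyond the scatter) and it brought in the seven-membered non-aromatic ring that compound 3 gives up. A step of similar size in the opposite direction is therefore expected in this assay here. The estimated change is a number 1.20 log units lower from compound 2 to compound 3 (beyond the scatter) overall. Compound 3 is estimated at 2.4 with an expected range from 1.9 to 2.9 in this measurement.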

Compound 3, distribution coefficient: 2.4
Beside the measured number, compound 3's estimate shows no gap at the digits printed, and the stated range covers the measured number.
By their numbers in this assay, from the lowest: compounds 3 and 1 (each within the scatter of the next); then compound 2.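

In this assay, the aromatic carbon opposite the ring nitrogen now shows a downward step as well as an upward one: a number 1.20 log units lower from compound 2 to compound 3 (beyond the scatter), on exchanging the seven-membered non-aromatic ring for the six-membered non-aromatic ring with 2 hetero atoms. With a number 0.20 log units lower from compound 1 to compound 3 (within the scatter), the groups of these two compounds cannot be told apart on this read-out. Nothing shown accounts for either step.

Going by these compounds, the ring size and the ring oxygen change together, so their shares of the step from compound 2 stay open. On these data alone, whether an amine in place of that oxygen would give a similar number also remains open.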